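Hydroxynaphthyl for Styryl in a Weakly Cytotoxic Series

The source may report more compounds than this note shows. Statements on the series, on what has been measured and on what is new or still open speak of the compounds shown alone.

The series rests on a shared core, seen in compound 1 `COc1cc(N2C(N)=C(C#N)C(c3ccc([N+](=O)[O-])cc3)C3=C2CC(C)(C)CC3=O)cc(OC)c1OC`, where a 3,4,5-trimethoxyphenyl group sits on the ring nitrogen and an aryl or alkenyl group on a saturated ring carbon. In a functional assay on Ehrlich cells (Mus musculus) for cytotoxicity (a higher number here means a weaker inhibitor, a lower number a stronger inhibitor), compound 1 gives 25000 nM. Compound 2 `COc1cc(N2C(N)=C(C#N)C(/C=C/c3ccccc3)C3=C2CC(C)(C)CC3=O)cc(OC)c1OC` carries a 2-phenylethenyl group on that saturated ring carbon; in this assay compound 2 is reported as "not active" (no number reported), so it stands without a number, behind compound 1 in what the readings show. Compound 3 `COc1cc(N2C(N)=C(C#N)C(c3c(O)ccc4ccccc34)C3=C2CC(C)(C)CC3=O)cc(OC)c1OC` differs from compound 2 in one place: 2-hydroxynaphthalen-1-yl in place of 2-phenylethenyl on a saturated ring carbon. Going by the values given here, no measured pair in this set maps a change of this kind, so the direction of the step is open. Given that compound 1 in this assay gives only 25000 nM and compound 2 gives "not active" (no number reported), the whole set sits in the weak range, and compound 3 is expected to remain there. Compound 3 is estimated in this assay at 40000 nM, within 10000 nM to 200000 nM, with a fair chance that no number is reported at all.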

Compound 3, half-maximal inhibitory concentration: 143000 nM
Compound 3: middle estimate off by 3.6-fold (0.55 log units), on the low side; the measured number falls inside the stated range.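

With compound 3, the saturated ring carbon gets its first readable step in this assay: 2-hydroxynaphthalen-1-yl in place of 4-nitrophenyl gives a 5.7-fold higher number from compound 1 to compound 3 (0.76 log units; beyond the scatter), so the group at this position does change the reading, and this change moves it toward weaker inhibition. The step from 2-phenylethenyl to 2-hydroxynaphthalen-1-yl cannot be read, as only one side of it has a number; compound 3 gives 143000 nM, whereas compound 2 is reported as not active, and that report fixes no order between the two. Nothing at hand accounts for the shift seen at this carbon.

Going by these compounds alone, the single step swaps a whole group for another, so it cannot say whether the second aromatic ring, the hydroxyl or the loss of the nitro group carries the change, and a plain naphthalen-1-yl or a 2-hydroxyphenyl would be needed to pull these apart. From the compounds shown here alone, it also remains open whether any other group on this carbon, such as a 4-aminophenyl or a 4-carboxyphenyl, would read stronger than compound 1 in this assay.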